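The compounds below may be only part of what the source reports. "The series", "measured", "known", "first", "only" and "open" are said of these compounds alone.

Measured compounds in a functional assay on MCF7 cells (Homo sapiens) for cytotoxicity, read by colorimetric assay and sulforhodamine B assay, with a stated time of 48 h; a lower number here means a stronger inhibitor, a higher number a weaker inhibitor:
compound 1 `COc1cc(/C=N/n2c(C)nc3c(cnn3-c3ccc(Cl)cc3)c2=O)ccc1O` gives 19800 nM
compound 2 `COc1ccc(/C=N/n2c(C)nc3c(cnn3-c3ccc(Cl)cc3)c2=O)cc1OC` gives 25000 nM
compound 3 `Cc1nc2c(cnn2S(=O)(=O)c2ccc(Cl)cc2)c(=O)n1/N=C/c1ccccc1` gives 22400 nM

The three numbers sit close together; compound 3 is within the scatter of both compound 2 and compound 1, so none of the three can be set apart from the others in this assay. Compound 4 `COc1ccc(/C=N/n2c(C)nc3c(cnn3S(=O)(=O)c3ccc(Cl)cc3)c2=O)cc1OC` is not yet measured. It differs from compound 3 in one place: 3,4-dimethoxyphenyl in place of phenyl on a carbon with a double bond to nitrogen.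

Among the compounds with values here, the only measured step that touches this part of the structure is the one from compound 1 to compound 2, which adds a methyl on an aromatic oxygen of the aryl group on the double-bonded carbon, and that step gave a 1.3-fold higher number from compound 1 to compound 2 (0.10 log units; within the scatter). Compound 2 already carries the 3,4-dimethoxyphenyl group that enters in compound 4, albeit on the core of compound 2 rather than the core of compound 3, and compound 2 and compound 3 lie within the scatter of each other. Nothing measured here points to a shift beyond the scatter in this assay for decorating the phenyl with two methoxy groups.

Compound 4 is therefore expected to give about 24000 nM in this assay, with a range of 12000 nM to 48000 nM. The expected step from compound 3 to compound 4 is a 1.1-fold higher number from compound 3 to compound 4 (0.03 log units; within the scatter), no more than the scatter.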

Compound 4, half-maximal inhibitory concentration: 33600 nM
Estimate against measurement, compound 4: 1.4-fold (0.15 log units) below; the range from low to high includes it.
By their numbers in this assay, from the lowest: compounds 1, 3, 2 and 4 (each within the scatter of the next).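

In this assay, within the data shown here, the change of phenyl to 3,4-dimethoxyphenyl on a carbon with a double bond to nitrogen can now be read directly on the core of compound 3, and it gives a 1.5-fold higher number from compound 3 to compound 4 (0.18 log units; within the scatter) for the full two-methoxy change, where the earlier compounds offered only a single methyl on an aromatic oxygen, on a different core. Among these compounds, the result also gives the first reading of the other place with the aryl group held fixed: (4-chlorophenyl)sulfonyl in place of 4-chlorophenyl on an aromatic nitrogen gives a 1.3-fold higher number from compound 2 to compound 4 (0.13 log units; within the scatter), so neither change separates the compounds in this assay at this level of scatter. No measurement at hand bears on the reason for either step.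

Still open, on these data alone, is whether an amine or a carboxylic acid on the aryl group would give a step beyond the scatter in this assay. The same holds for a longer chain in place of the methyl on the shared core.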